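Methoxy in Place of Fluorophenyl on the Shared Core

This account rests on a few compounds, and the source may have more. Where it says the series, first, only, none or still open, it means among the compounds named here.

Among the compounds with values here, compound 2 `O=C(CCCCCCc1nc2ccc(-c3ccc(F)cc3)cc2[nH]1)NO` holds the lowest of the three numbers measured so far. In a functional assay on SK-OV-3 cells (Homo sapiens) for cytotoxicity (a lower number here means a stronger inhibitor, a higher number a weaker inhibitor), compound 2 gives 1200 nM. The nearest of the others is compound 3 `O=C(CCCCCCc1nc2cccc(Cl)c2[nH]1)NO`, which in this assay gives 10000 nM, a gap beyond the scatter. Furthest is compound 1 `O=C(CCCCCc1nc2ccccc2[nH]1)NO`, which in this assay gives 11000 nM, also beyond the scatter. Neither compound 1 nor compound 3 differs from compound 2 in a single place, so their values only show where compound 2 stands.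

Compound 4 `COc1ccc2nc(CCCCCCC(=O)NO)[nH]c2c1` has not yet been measured. It differs from compound 2 as follows: methoxy in place of 4-fluorophenyl on an aromatic carbon. Within the data shown here, no step between two measured compounds that differ in one place is available to set the size of this change. Both compound 1 at 11000 nM and compound 3 at 10000 nM, neither carrying the 4-fluorophenyl, sit well above compound 2, so the expected direction in this assay is toward a higher number, beyond the scatter. Compound 4 is therefore expected to give 5000 nM in this assay, within a range from 1500 nM to 15000 nM. This expectation corresponds to a step of a 4.2-fold higher number from compound 2 to compound 4 (0.62 log units; beyond the scatter).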

Compound 4, half-maximal inhibitory concentration: 11000 nM
Compound 4: middle estimate off by 2.2-fold (0.34 log units), on the low side, within the range that was stated.
By their numbers in this assay, from the lowest: compound 2; then compounds 3, 1 and 4 (each within the scatter of the next).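

In this assay, methoxy in place of 4-fluorophenyl on an aromatic carbon gives a 9.2-fold higher number from compound 2 to compound 4 (0.96 log units; beyond the scatter), the first step shown between measured compounds that differ in one place. This shows that the low number of compound 2 is tied to what sits at this position of the shared core, since only the group changes: 4-fluorophenyl, with 7 heavy atoms and a six-membered aromatic ring of carbon only, gives way to methoxy, with 2 heavy atoms and no ring. Nothing shown explains why the number moves with this change, so the step stands as an observation only.

The compounds shown leave open whether the lower number of compound 2 rests on the aromatic ring or on the fluorine it carries, which a plain phenyl at the same position would begin to separate, and whether a pyridyl or a 4-chlorophenyl would keep it. They also leave open whether the same exchange gives a step of similar size with a shorter chain leading to the hydroxamic acid.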